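Aryl exchange in a flat series

This account rests on a few compounds, and the source may have more. Where it says the series, first, only, none or still open, it means among the compounds named here.

In a functional assay on MDA-MB-231 cells (Homo sapiens) for cytotoxicity, read by MTT assay, with a stated time of 48 h (on this read-out lower numbers stand for stronger inhibition and higher numbers for weaker inhibition), compound 1 (`COc1ccc(OC)c(C2=NOC(COc3ccc(-c4nnnn4-c4cc(OC)c(OC)c(OC)c4)cc3N)C2)c1`) gives 3500 nM while compound 2 (`COc1ccc(C2=NOC(COc3ccc(-c4nnnn4-c4cc(OC)c(OC)c(OC)c4)cc3N)C2)cc1N`) gives 3000 nM and compound 3 (`COc1cc(C2=NOC(COc3ccc(-c4nnnn4-c4cc(OC)c(OC)c(OC)c4)cc3N)C2)cc(OC)c1OC`) gives 3230 nM with no separation among the three. Compound 3 stands level with the other two, its steps being a 1.1-fold higher number from compound 2 to compound 3 (0.03 log units; within the scatter) and a 1.1-fold lower number from compound 1 to compound 3 (0.03 log units; within the scatter) at the same place. The remaining exchange there, a 1.2-fold lower number from compound 1 to compound 2 (0.07 log units; within the scatter) too, stays within the scatter. Compound 4 (`COc1ccc(C2=NOC(COc3ccc(-c4nnnn4-c4cc(OC)c(OC)c(OC)c4)cc3N)C2)cc1O`) has 3-hydroxy-4-methoxyphenyl in place of 3,4,5-trimethoxyphenyl on a carbon with a double bond to nitrogen. On these data alone, that group itself is untested, the closest measured one being the 3-amino-4-methoxyphenyl of compound 2. In this assay no step beyond the scatter is therefore expected. The expected change is a 1.1-fold lower number from compound 3 to compound 4 (0.03 log units; within the scatter) and no more. Compound 4 is estimated at 3000 nM with an expected range from 1300 nM to 6500 nM on this read-out.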

Compound 4, half-maximal inhibitory concentration: 3380 nM
The estimate for compound 4 lay 1.1-fold (0.05 log units) below the measured number; low and high end bracket the measured number.
By their numbers in this assay, from the lowest: compounds 2, 3, 4 and 1 (each within the scatter of the next).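

Placing 3-hydroxy-4-methoxyphenyl on the carbon with a double bond to nitrogen leaves the read-out in this assay flat against 3,4,5-trimethoxyphenyl (a 1.0-fold higher number from compound 3 to compound 4 (0.02 log units; within the scatter)) and against 2,5-dimethoxyphenyl (a 1.0-fold lower number from compound 1 to compound 4 (0.02 log units; within the scatter)). Hydroxy in place of amino on the aromatic carbon, a change at a single substituent, also stays within the scatter (a 1.1-fold higher number from compound 2 to compound 4 (0.05 log units; within the scatter)). No measurement bears on why this position stays flat.

Still open, on these data alone, is whether anything other than a substituted phenyl here, such as a pyridine ring, a carboxylic acid or a longer alkyl chain, would move the number beyond the scatter.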